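The source may hold more compounds than are shown below. What is called first, only, known or untested is meant among the compounds shown, and "the series" means these compounds.

The study follows cytotoxicity in an ADME assay on BJ cells (Homo sapiens) for cytotoxicity, read by CellTiter-Glo and resazurin assay, with a stated time of 72 h; on this read-out lower numbers stand for an effect already at smaller amounts and higher numbers for an effect only at larger amounts of compound. Compound 1 `CCOC(=O)CCCCCOc1cccc(CN(C(=O)c2ccc(-c3cccc(N(C)C)c3)cc2)C(C)C)c1` opens the series. In this assay compound 1 gives only a limit of the assay, > 26000 nM. Compound 2 `CCOC(=O)CCCCCOc1cccc(CN(C(=O)c2ccc(-c3cc(OC)cc(OC)c3)cc2)C(C)C)c1` carries a 3,5-dimethoxyphenyl where compound 1 carries a 3-(dimethylamino)phenyl. In this assay compound 2 likewise gives only a limit, > 26000 nM. The step that the two limits leave unreadable from compound 1 to compound 2 therefore cannot be read, and compound 2 stands where every value shown stands, at the limit (the limit of > 26000 nM in this assay, at which 2 of the 2 values shown sit). Compound 3 `CCOC(=O)CCCCCOc1cccc(CN(C(=O)c2ccc(-c3cccc(S(C)(=O)=O)c3)cc2)C(C)C)c1` is not yet measured; it differs from compound 2 by 3-(methylsulfonyl)phenyl in place of 3,5-dimethoxyphenyl on an aromatic carbon. Among the compounds with values here, the one measured step, from a 3-(dimethylamino)phenyl to a 3,5-dimethoxyphenyl, is the only comparison of this kind, and its size is unknown, so it gives no size to carry over. Nothing measured points to a step beyond the scatter in this assay in either direction, and a result at the limit again looks most likely. Compound 3 is expected to give 40000 nM in this assay, within 15000 nM to 120000 nM. That estimate means an expected step that the limit leaves unreadable from compound 2 to compound 3.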

Compound 3, half-maximal effective concentration: > 26000 nM
Compound 3 ended at the assay's limit; the forecaster's own chance of this, stated with the estimate: 85%; the middle value lies beyond the limit too.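

Compound 3 joins compound 1 and compound 2 at the limit, so no step among these three compounds can be read in this assay: the limit of > 26000 nM in this assay, at which 3 of the 3 values shown sit.

The compounds shown leave open whether any change at this aromatic position would give a measurable value in this assay, and how large any differences between these three compounds might be.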